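The source may hold more compounds than are shown below. What is called first, only, known or untested is meant among the compounds shown, and "the series" means these compounds.

Measured so far:
compound 1 `N=C(NCCCc1c[nH]cn1)NCCCC(c1ccccc1)c1ccccn1` — 1
compound 2 `N=C(NCCCc1c[nH]cn1)NCCC(c1ccccc1)c1ccccn1` — 1

In a functional assay on cardiac atrium for agonist activity at histamine H2 receptor (Cavia porcellus) (on this read-out lower numbers stand for smaller maximal responses and higher numbers for larger maximal responses), compound 1 gives 1. Compound 2, which carries the shorter chain between the guanidine and the branching carbon, gives 1; the two values are level at the digits shown, so the shortening of that chain leaves the maximal response unchanged within the scatter. Both compounds reach the full response of the reference agonist.

Compound 3 `N=C(NCCCc1c[nH]cn1)NCCC(c1ccc(F)cc1)c1ccccn1` is the next member. It differs from compound 2 in one place: fluoro in place of hydrogen on an aromatic carbon. Among the measured compounds shown here, no pair so far separates this change from anything else, so the expectation rests on the two values alone, which show the maximal response holding at the reference level across a change elsewhere in the molecule. The expected step in this assay from compound 2 to compound 3 is a number 0.050 lower from compound 2 to compound 3 (within the scatter), no move beyond the scatter. Compound 3 is therefore estimated at 0.95, with a range of 0.8 to 1.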

Compound 3, intrinsic activity: the largest response reached, as a fraction of the reference agonist's: 1
Beside the measured number, compound 3's estimate is 0.050 below it; the measured number falls inside the stated range.
By their numbers in this assay, from the lowest: compounds 1, 2 and 3 (each within the scatter of the next).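

In this assay, among the compounds shown here, the phenyl to 4-fluorophenyl exchange shows no change at the digits printed from compound 2 to compound 3 (within the scatter) and is the only step here that touches an aromatic ring, since compound 1 and compound 2 differ only in the chain. Fluoro on this aromatic carbon, para to a large group, is therefore tolerated on this read-out, and compound 3 gives 1, the full response of the reference agonist. Nothing at hand accounts for this result.

Still open, from the compounds shown here alone, is whether a larger group in the same place, such as chloro, methoxy or trifluoromethyl, or an amine, would hold the maximal response at that level. Also open, going by these compounds, are fluoro on the other aromatic ring and how much agonist concentration each compound needs, which a maximal response does not report.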